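Substituent swaps on the aryl ring of the shared core

A few compounds are considered here, and "the series" means these few. Any claim that something is new, unique, unknown or untested is made for them only; others in the source may bear on it.

Measured in a functional assay on the whole organism (strain Wistar) with Rattus norvegicus as the target, with stated times of 30 min and 4 h, at a dose of 20 mg/kg by the intraperitoneal route; a higher number here means a stronger effect of the compound at the dose given, a lower number a weaker effect:
compound 1, `O=S(=O)(Nc1ccncc1Nc1cccc(Br)c1)C(F)(F)F`: 28.5%
compound 2, `O=S(=O)(Nc1ccncc1Nc1ccc(F)c(Cl)c1)C(F)(F)F`: 64.7%
compound 3, `O=S(=O)(Nc1ccncc1Nc1cccc(Cl)c1)C(F)(F)F`: 16.4%

Compound 3 stands lowest of the three numbers. Its nearest neighbour is compound 1, reached by the step of a number 12.1 percentage points lower from compound 1 to compound 3 (beyond the scatter); its furthest is compound 2, reached by the step of a number 48.3 percentage points lower from compound 2 to compound 3 (beyond the scatter). Both steps end at compound 3 and both run downward, one modest and one large.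

Compound 4, `Cc1cccc(Nc2cnccc2NS(=O)(=O)C(F)(F)F)c1`, differs from compound 3 in one place: methyl in place of chloro on an aromatic carbon. Within the data shown here, no measured step replaces a halogen by methyl, so neither step above bears on the change directly. Among the measured compounds shown here, what the two steps show is only that every change made to the ring substituents in this set moved the number in this assay by more than the scatter, so a step of some size from compound 3 to compound 4 seems likelier than none. Its direction is not fixed by anything measured; the step is therefore expected to be small and either way. For compound 4 the expected value is 22%, with a range from 8% to 40%, corresponding to an expected step of a number 5.6 percentage points higher from compound 3 to compound 4 (within the scatter).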

Compound 4, a percentage reported as activity, at one dose (the size of the read-out at that dose, not a potency): 50.2%
The estimate for compound 4 lay 28.2 percentage points below the measured number; the whole stated range lies below it.
By their numbers in this assay, from the lowest: compound 3; then compound 1; then compound 4; then compound 2.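

In this assay, the change from 3-chlorophenyl to 3-methylphenyl gives a number 33.8 percentage points higher from compound 3 to compound 4 (beyond the scatter) and is a large step, while replacing bromo by methyl at the same place gives a number 21.7 percentage points higher from compound 1 to compound 4 (beyond the scatter) and is a modest one. The earlier steps shown here involved only halogens at this place, meta to a large group, so the new result adds a carbon substituent: among the singly substituted compounds 1, 3 and 4, methyl gives the highest number, and the halogens do not set the upper end of the read-out at this place. Compound 2 stands outside this comparison, since it differs from compound 4 in more than one place, and nothing in the data shown explains why methyl outperforms chloro and bromo here.

Still open, on these data alone, is whether the rise continues with an ethyl group, a methoxy group or an amine at the same place, or belongs to methyl alone. Also open, as far as these compounds go, is whether the fluoro that separates compound 2 from compound 3 would raise the number on the 3-methylphenyl ring as it does on the 3-chlorophenyl ring, as seen in a number 48.3 percentage points lower from compound 2 to compound 3 (beyond the scatter) read in reverse.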